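Ester chain homologation on the aspartate-type side chain

This account rests on a few compounds, and the source may have more. Where it says the series, first, only, none or still open, it means among the compounds named here.

compound 1 `CC[C@H](C)[C@@H](NC(=O)Cn1cc(C2=C(c3c[nH]c4ccccc34)C(=O)N(C)C2=O)c2ccccc21)C(=O)OC` gives > 100000 nM in a functional assay on Bel-7402 cells (Homo sapiens) for cytotoxicity, read by MTT assay, with a stated time of 24 h; on this read-out lower numbers stand for stronger inhibition and higher numbers for weaker inhibition
compound 2 `COC(=O)C[C@@H](NC(=O)Cn1cc(C2=C(c3c[nH]c4ccccc34)C(=O)N(C)C2=O)c2ccccc21)C(=O)OC` gives 9360 nM
compound 3 `COC(=O)CC[C@@H](NC(=O)Cn1cc(C2=C(c3c[nH]c4ccccc34)C(=O)N(C)C2=O)c2ccccc21)C(=O)OC` not yet measured

Among the compounds with values here, compound 2 stands as the only actual number in this assay; the other value shown is a limit. For compound 1 the value is a limit of the assay, (the limit of > 100000 nM in this assay, at which 1 of the 2 values shown sits), and not a number. Within the data shown here, the one measured step, an at least 10-fold lower number from compound 1 to compound 2 (1.02 log units; beyond the scatter), concerns a different exchange, sec-butyl for (methoxycarbonyl)methyl, and so bears on the new step only indirectly, showing that this carbon tolerates a large move.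

Compound 3 differs from compound 2 by (methoxycarbonyl)methyl in place of methoxycarbonyl on a saturated chain carbon, two bonds along the chain from an amide-type nitrogen and a carbonyl carbon. Among the measured compounds shown here, no measured step covers this lengthening, so no shift beyond the scatter is expected: the step of a 1.0-fold lower number from compound 2 to compound 3 (0.02 log units; within the scatter) is estimated to stay within the usual scatter. Compound 3 is therefore expected to give 9000 nM, in the range 3000 nM to 30000 nM.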

Compound 3, half-maximal inhibitory concentration: 47400 nM
Beside the measured number, compound 3's estimate is 5.3-fold (0.72 log units) below it, outside the stated range (above it).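

In this assay the side chain length at this carbon matters, which compound 1 and compound 2 alone could not show: the added chain carbon gives a 5.1-fold higher number from compound 2 to compound 3 (0.70 log units; beyond the scatter) and so the shorter ester chain of compound 2 is preferred here. The longer 2-(methoxycarbonyl)ethyl chain still compares favourably with sec-butyl, with an at least 2.1-fold lower number from compound 1 to compound 3 (0.32 log units; beyond the scatter) as the printed step, so an ester-bearing side chain keeps an edge over sec-butyl at both lengths shown. The value of compound 1 is a limit and not a number, so that step is a bound: the limit of > 100000 nM in this assay, at which 1 of the 3 values shown sits.

Within the data shown here, with only two ester chain lengths, no trend with length can be claimed, and a still longer chain remains open. Also open, going by these compounds, is whether a carboxylic acid or an amine could stand in place of the side chain methoxycarbonyl.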